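The compounds below may be only part of what the source reports. "The series", "measured", "known", "first", "only" and "open" are said of these compounds alone.

Measured compounds and their values:

Compound 1 `COc1cc(O)cc(O)c1C(=O)/C=C/c1ccc(O)cc1`: 40200 nM
Compound 2 `COc1cc(/C=C/C(=O)c2c(O)cc(O)cc2OC)ccc1O`: > 50000 nM
Compound 3 `COc1ccc(/C=C/C(=O)c2c(O)cc(O)cc2OC)cc1OC`: 18500 nM

All three were tested in a functional assay on HepG2 cells (Homo sapiens) for inhibition, read by MTT assay, with a stated time of 72 h; on this read-out higher numbers stand for weaker inhibition and lower numbers for stronger inhibition. For compound 2 the result is only a limit of this assay, not a number. Compound 1 and compound 2 differ by a single change, (methoxy in place of hydrogen on an aromatic carbon), and this gave an at least 1.2-fold higher number from compound 1 to compound 2 (0.09 log units; that floor lies within the scatter). Compound 2 and compound 3 differ by an at least 2.7-fold lower number from compound 2 to compound 3 (0.43 log units; beyond the scatter), which came with a methyl in place of hydrogen on an oxygen on an aromatic ring. Of the three, compound 3 gives the lowest number. The difference between the core of compound 1 and the core of compound 3 is not broken down here.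

Compound 4 `COc1cc(OC)c(OC)cc1/C=C/C(=O)c1c(O)cc(O)cc1OC` is not yet measured. It differs from compound 3 by methoxy in place of hydrogen on an aromatic carbon. This is the same kind of change as from compound 1 to compound 2, but the surroundings differ: there the new group sat ortho to a hydroxy group and meta to a large group, here it sits ortho to a large group, meta to a methoxy group and para to a methoxy group. The earlier step, an at least 1.2-fold higher number from compound 1 to compound 2 (0.09 log units; that floor lies within the scatter), sits at a floor within the scatter, so it gives little guidance. Compound 4 is therefore expected to land near compound 3, with an estimated 1.2-fold lower number from compound 3 to compound 4 (0.09 log units; within the scatter), giving an expected 15000 nM within a range of 6000 nM to 40000 nM.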

Compound 4, half-maximal inhibitory concentration: 18700 nM
For compound 4 the middle estimate is 1.2-fold (0.10 log units) below the measured one; the measured number falls inside the stated range.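

In this assay, methoxy in place of hydrogen on an aromatic carbon gave a 1.0-fold higher number from compound 3 to compound 4 (0.00 log units; within the scatter), so on this core the added group leaves the number where it was, within the usual scatter. This does not show that the change behaves the same way on both cores, as the earlier step is only a floor and could hide a larger shift: the same change on two cores in this assay, an at least 1.2-fold higher number (0.09 log units; that floor lies within the scatter) from compound 1 to compound 2 and a 1.0-fold higher number (0.00 log units; within the scatter) from compound 3 to compound 4; the limit leaves it open whether they differ. Compound 2 gives only a limit of the assay, not a number: the limit of > 50000 nM in this assay, at which 1 of the 4 values shown sits.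

The compounds shown leave open whether a methoxy group would give the same result at other places on this ring, as only two examples of the change are at hand. They also leave open what an amine, a carboxylic acid or a longer chain would do in place of the methoxy group on the core of compound 4.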